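Benzyl on the oxygen: compound 2 to compound 3

The source may report more compounds than this note shows. Statements on the series, on what has been measured and on what is new or still open speak of the compounds shown alone.

Going by the values given here, in a functional assay on MCF7 cells (Homo sapiens) for antiproliferative activity, read by MTT assay, with a stated time of 72 h (a lower number here means a stronger inhibitor, a higher number a weaker inhibitor), compound 2 (`CC1=CC[C@H]2[C@H](CC[C@]2(C)O)C(C)(C)[C@@H]1CC[C@H]1[C@]2(C)CC/C(=N/O)C(C)(C)O[C@H]2CC[C@@]1(C)O`) gives 46800 nM as the only number so far. Compound 1 (`CC1=CC[C@H]2[C@H](CC[C@]2(C)O)C(C)(C)[C@@H]1CC[C@H]1[C@]2(C)CC[C@H](OC(=O)NS(=O)(=O)c3ccc(C)cc3)C(C)(C)O[C@H]2CC[C@@]1(C)O`) reads > 50000 nM and this is a limit of the assay, not a number. Compound 3 (`CC1=CC[C@H]2[C@H](CC[C@]2(C)O)C(C)(C)[C@@H]1CC[C@H]1[C@]2(C)CC/C(=N/OCc3ccccc3)C(C)(C)O[C@H]2CC[C@@]1(C)O`) takes benzyl in place of hydrogen on an oxygen of compound 2 (benzyl in place of hydrogen on an oxygen). Among the compounds with values here, no measured step exists to scale from. In this assay a modest shift towards stronger inhibition is expected. The estimated move is a 1.6-fold lower number from compound 2 to compound 3 (0.19 log units; within the scatter) and may not clear the usual scatter. For compound 3 the expected value is 30000 nM (estimated range 12000 nM to 50000 nM).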

Compound 3, half-maximal inhibitory concentration: > 50000 nM
Compound 3 was reported as a limit; the forecaster's own chance of this, stated with the estimate: 30%; middle value at least 1.6-fold (0.22 log units) from the limit.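

In this assay, benzyl on the oxygen bound to the double-bonded nitrogen gives an at least 1.0-fold higher number from compound 2 to compound 3 (0.02 log units; that floor lies within the scatter) and so brings no stronger inhibition at this position. On these data alone, compound 3 gives > 50000 nM, which is a limit of the assay and not a number, so the step is only a floor and its true size stays unknown. This first readable step at this oxygen ends at the same limit as the other capped value in the series: the limit of > 50000 nM in this assay, at which 2 of the 3 values shown sit.

As far as these compounds go, whether a methyl group or an aminoethyl chain on this oxygen would give a value clear of that limit remains open.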